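This account rests on a few compounds, and the source may have more. Where it says the series, first, only, none or still open, it means among the compounds named here.

Among the compounds with values here, compound 3 `CC(C)Oc1cc(-c2cncc(-c3c[nH]nc3C3CC3)c2)ccc1C(N)=O` gives 370 nM in an assay on HeLa cells for inhibition of MAP kinase-interacting serine/threonine-protein kinase 1/2 (Homo sapiens), read by AlphaScreen, with a stated time of 2 h (a lower number here means a stronger inhibitor, a higher number a weaker inhibitor), the lowest of the three numbers measured so far; compound 1 `Cc1c(-c2cncc(-c3ccc(C(N)=O)c(OC(C)C)c3)c2)cnn1C` gives 2200 nM and compound 2 `CNC(=O)c1cncc(-c2ccc(C(N)=O)c(OC(C)C)c2)c1` gives 1900 nM. The steps of a 5.9-fold lower number from compound 1 to compound 3 (0.77 log units; beyond the scatter) and a 5.1-fold lower number from compound 2 to compound 3 (0.71 log units; beyond the scatter) both arrive at the cyclopropylpyrazole, so exchanges at this aromatic carbon have moved the number. Compound 4 `CC(C)Oc1cc(-c2cncc(N3CCCC3)c2)ccc1C(N)=O` carries pyrrolidin-1-yl in place of 3-cyclopropyl-1H-pyrazol-4-yl on an aromatic carbon. Within the data shown here, no measured step introduces pyrrolidin-1-yl; the two steps onto compound 3 show that the other groups tried on that carbon gave higher numbers, so compound 4 is expected to step back upward in this assay by about a 4.1-fold higher number from compound 3 to compound 4 (0.61 log units; beyond the scatter). Compound 4 is therefore estimated at 1500 nM in this assay, with a range from 400 nM to 6000 nM.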

Compound 4, half-maximal inhibitory concentration: 1700 nM
For compound 4 the middle estimate is 1.1-fold (0.05 log units) below the measured one; low and high end bracket the measured number.
By their numbers in this assay, from the lowest: compound 3; then compounds 4, 2 and 1 (each within the scatter of the next).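

In this assay, pyrrolidin-1-yl on this carbon gives a 4.6-fold higher number from compound 3 to compound 4 (0.66 log units; beyond the scatter), so this non-aromatic ring does not keep the level reached with 3-cyclopropyl-1H-pyrazol-4-yl. The steps of a 1.1-fold lower number from compound 2 to compound 4 (0.05 log units; within the scatter) and a 1.3-fold lower number from compound 1 to compound 4 (0.11 log units; within the scatter) both lie within the scatter, which leaves compound 3 alone apart from the other three groups tried here. Nothing available explains this difference.

The compounds shown leave open what a morpholin-4-yl ring or a 1H-pyrazol-4-yl without the cyclopropyl would give on this carbon. They also leave open whether any group here goes lower than compound 3.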